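This account rests on a few compounds, and the source may have more. Where it says the series, first, only, none or still open, it means among the compounds named here.

Compound 1 `CC(C)(C)c1ccc(C(=O)/C=C/c2ccc([N+](=O)[O-])o2)cc1` stands at the edge of what this study can resolve. In an ADME assay on THP-1 cells (Homo sapiens) for cytotoxicity, read by resazurin assay, with a stated time of 72 h (a higher number here means that more compound is tolerated, a lower number that less compound is tolerated), compound 1 gives > 50000 nM, which is a limit of the assay rather than a number. Its neighbour compound 2 `CC(C)(C)c1ccc(C(=O)/C=C/c2ccco2)cc1` carries hydrogen in place of nitro on an aromatic carbon, and in this assay compound 2 likewise gives > 50000 nM, again a limit. The step that the two limits leave unreadable from compound 1 to compound 2 thus has no readable size, because both values sit at the limit of > 50000 nM in this assay, at which 2 of the 2 values shown sit.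

The untested compound 3 `O=C(/C=C/c1ccc([N+](=O)[O-])o1)c1ccc(-c2ccccc2)cc1` is reached from compound 1 by phenyl in place of tert-butyl on an aromatic carbon. Within the data shown here, only the step from compound 1 to compound 2 bears on this change, and it was left unreadable by the two limits. Among the measured compounds shown here, no measured step therefore points to a change in this assay beyond the scatter in either direction. Compound 3 is accordingly expected to give 50000 nM in this assay, within 20000 nM to 120000 nM, most likely again as a limit. The step of a number no higher from compound 1 to compound 3 (the limit leaves the size open) is the estimated consequence, and compound 3 was then measured.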

Compound 3, half-maximal cytotoxic concentration: 50400 nM
Compound 3: middle estimate off by 1.0-fold (0.00 log units), on the low side; low and high end bracket the measured number.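

No new step can be read: in this assay the result for compound 1 is only a limit, so the change to compound 3, phenyl in place of tert-butyl, has no readable size. The compounds shown leave open where the true values of compound 1 and compound 2 lie, and whether either change alters tolerance at all.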